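Oxazole ketone series: sulfonate replaces chloromethyl on the pyridyl

The source may report more compounds than this note shows. Statements on the series, on what has been measured and on what is new or still open speak of the compounds shown alone.

Measured so far:
compound 1 `O=C(CCCCCCc1ccccc1)c1ncc(-c2ccc(CO)cn2)o1` — 3.2 nM
compound 2 `O=C(CCCCCCc1ccccc1)c1ncc(-c2ccc(CCl)cn2)o1` — 22.4 nM

Compound 1 and compound 2 share the same core and differ only in the group on the six-membered ring with one nitrogen. In an assay for inhibition of Fatty-acid amide hydrolase 1 (Rattus norvegicus), using a Dixon plot (a lower number here means a stronger inhibitor, a higher number a weaker inhibitor), compound 1 gives 3.2 nM, and in this assay compound 2 gives 22.4 nM, the higher of the two numbers recorded. Among the compounds with values here, the single step known here is a 7.0-fold higher number from compound 1 to compound 2 (0.85 log units; beyond the scatter).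

Compound 3 `CCOS(=O)(=O)/C=C/c1ccc(-c2cnc(C(=O)CCCCCCc3ccccc3)o2)nc1` is not yet measured. It differs from compound 2 in one place: 2-(ethoxysulfonyl)ethenyl in place of chloromethyl on an aromatic carbon. The place is the aromatic carbon two atoms from the ring nitrogen, para to a large group.

Within the data shown here, the only measured step concerns the same position, but it exchanged one small group for another; nothing measured speaks to an entering 2-(ethoxysulfonyl)ethenyl group. A change of this size at a position that has already shifted the number beyond the scatter could move it either way. The working expectation is a step of about a 1.5-fold lower number from compound 2 to compound 3 (0.17 log units; within the scatter), with compound 3 estimated at 15 nM, in the range 3 nM to 80 nM.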

Compound 3, inhibition constant: 2.1 nM
Estimate against measurement, compound 3: 7.1-fold (0.85 log units) above, and the stated range ends above it.
By their numbers in this assay, from the lowest: compounds 3 and 1 (each within the scatter of the next); then compound 2.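

In this assay, the aromatic carbon two atoms from the ring nitrogen accepts a far larger group than the earlier compounds had shown: an 11-fold lower number from compound 2 to compound 3 (1.03 log units; beyond the scatter) comes with 2-(ethoxysulfonyl)ethenyl, of 8 heavy atoms, replacing chloromethyl, of 2 heavy atoms. Measured against hydroxymethyl, the same group gives a 1.5-fold lower number from compound 1 to compound 3 (0.18 log units; within the scatter) and so leaves the two compounds level, which makes compound 2 the one that stands apart among these three, while the size of the group at this position does not order the series. Nothing measured here accounts for either step.

On these data alone, whether the result belongs to the ethenyl link or to the ethoxysulfonyl end stays open, and a saturated ethyl link carrying the same sulfonate, or a carboxylic acid on the ethenyl link, would separate the two. Only this one position varies across the compounds shown, so it is also open whether the same order among the three groups would hold with a shorter chain in place of the shared phenyl-ended chain on the ketone.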